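The source may report more compounds than this note shows. Statements on the series, on what has been measured and on what is new or still open speak of the compounds shown alone.

Measured compounds:
compound 1 `CCC(=O)N1CCc2cc(CNC(=O)c3ccccc3)ccc21`: 87%
compound 2 `CC(C)CC(=O)N1CCc2cc(CNC(=O)c3cccnc3)ccc21`: 86%
compound 3 `CC(C)C(=O)N1CCc2cc(CNC(=O)c3ccccc3)ccc21`: 100%

These three compounds were tested in an assay on HEK293 cells for inhibition of Indoleamine 2,3-dioxygenase 1 (Homo sapiens), tested at 10 uM; on this read-out higher numbers stand for more inhibition at the one concentration tested (going by the name of the read-out) and lower numbers for less inhibition. Compound 1 stands second highest of the three; its number and that of compound 2 lie within the scatter of each other, while compound 3 sits higher, with a number 13 percentage points higher from compound 1 to compound 3 (beyond the scatter). Compound 4 `CCC(=O)N1CCc2cc(CNC(=O)c3cccc(Cl)c3)ccc21` has not yet been measured. It differs from compound 1 in one place: chloro in place of hydrogen on an aromatic carbon. Within the data shown here, no measured step touches the phenyl ring of the benzamide, and the one measured step concerns a methyl on the saturated chain, so nothing here speaks directly to a chloro on the aromatic carbon. The step to compound 4 is therefore expected to be small, a number 1 percentage points higher from compound 1 to compound 4 (within the scatter), not beyond the scatter. Compound 4 is estimated to give 88%, between 72% and 100%.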

Compound 4, a percentage reported as inhibition, at one concentration (the size of the read-out at that concentration, not a potency): 77%
Compound 4: the middle estimate sits 11 percentage points above what was measured; measured number inside the range.
By their numbers in this assay, from the lowest: compounds 4, 2 and 1 (each within the scatter of the next); then compound 3.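

Replacing hydrogen with chloro on this aromatic carbon, the change from phenyl to 3-chlorophenyl, gives a number 10 percentage points lower from compound 1 to compound 4 (within the scatter). This first look at a change on this ring therefore shows that a single chlorine here leaves the read-out within the usual scatter of compound 1. No supporting measurement bears on this result. Still open, from the compounds shown here alone, is whether an amine, a methoxy group or a nitrile on the same aromatic carbon would also stay within the scatter. Also open, going by these compounds, is whether the chloro would give a similar step on compound 3.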